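The compounds below may be only part of what the source reports. "The series", "measured", "known", "first", "only" and "open" are said of these compounds alone.

In a functional assay on HeLa cells (Homo sapiens) for cytotoxicity, read by MTT assay, with a stated time of 48 h (a lower number here means a stronger inhibitor, a higher number a weaker inhibitor), compound 1 `COc1ccc(/C=C/c2cc(OC)c(OC)c(OC)c2-c2ccc(OC)cc2)cc1` gives 19000 nM, while compound 2 `C=C(c1ccc(OC)cc1)c1cc(OC)c(OC)c(OC)c1-c1ccc(OC)cc1` gives 72000 nM. Compound 2 therefore has the higher of the two numbers and is the weaker inhibitor of the pair. Compound 3 `C=C(c1ccc(OC)cc1)c1cc(OC)c(OC)c(OC)c1-c1ccc2ccccc2c1` keeps the 1-(4-methoxyphenyl)ethenyl group of compound 2 and carries one change: naphthalen-2-yl in place of 4-methoxyphenyl on an aromatic carbon. Among the measured compounds shown here, the only measured step is a 3.8-fold higher number from compound 1 to compound 2 (0.58 log units; beyond the scatter), a modest one that comes from swapping 2-(4-methoxyphenyl)ethenyl for 1-(4-methoxyphenyl)ethenyl. It involves a different group, so it gives neither a size nor a direction for putting naphthalen-2-yl in place of 4-methoxyphenyl. No clear shift is therefore expected in this assay, and the expected step, a 1.2-fold lower number from compound 2 to compound 3 (0.08 log units; within the scatter), stays within the usual scatter. Compound 3 is estimated at 60000 nM, with an expected range from 20000 nM to 160000 nM.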

Compound 3, half-maximal inhibitory concentration: 35000 nM
Estimate against measurement, compound 3: 1.7-fold (0.23 log units) above; the measured number falls inside the stated range.
By their numbers in this assay, from the lowest: compounds 1 and 3 (each within the scatter of the next); then compound 2.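

In this assay, the aromatic carbon that carries the 4-methoxyphenyl group in compound 2 responds to a change of group: naphthalen-2-yl there gives a 2.1-fold lower number from compound 2 to compound 3 (0.31 log units; beyond the scatter), a modest step that lies beyond the scatter. The earlier step concerned only the ethenyl link, whereas this one shows that the oxygen of the methoxy group is not required at this position for the activity seen, and that a second aromatic ring is accepted there. Nothing measured here accounts for the shift.

The swap removes the oxygen and adds a ring at the same time, so the compounds shown cannot tell these two changes apart; a plain phenyl group would help separate them. Also open, as far as these compounds go, are how an amine at this position would behave and whether naphthalen-2-yl has a similar effect alongside the 2-(4-methoxyphenyl)ethenyl group of compound 1.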